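The source may report more compounds than this note shows. Statements on the series, on what has been measured and on what is new or still open speak of the compounds shown alone.

Measured so far:
compound 1 `Oc1ccc(-c2cc(-c3ccccc3F)cc(-c3ccccc3O)n2)cc1`: > 50000 nM, a limit of the assay rather than a number
compound 2 `Oc1cccc(-c2cc(-c3cccc(C(F)(F)F)c3)cc(-c3ccccc3O)n2)c1`: 6340 nM

In a functional assay on T47D cells (Homo sapiens) for inhibition (a higher number here means a weaker inhibitor, a lower number a stronger inhibitor), compound 2 gives 6340 nM. Within the data shown here, that is the only real number here; the other reading is the limit of > 50000 nM in this assay, at which 1 of the 2 values shown sits. Compound 3 `Oc1ccc(-c2cc(-c3cccc(C(F)(F)F)c3)cc(-c3ccccc3O)n2)cc1` has not been measured yet. It differs from compound 2 by 4-hydroxyphenyl in place of 3-hydroxyphenyl on an aromatic carbon. Among the measured compounds shown here, no measured pair shows this change on its own, so its size cannot be read from a step. Compound 1 also carries a 4-hydroxyphenyl and gave only a limit, yet it differs from compound 3 in a second place too. For compound 3 the estimated value is 15000 nM, expected between 4000 nM and 60000 nM. The expected step is a 2.4-fold higher number from compound 2 to compound 3 (0.37 log units; beyond the scatter), toward weaker inhibition.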

Compound 3, half-maximal inhibitory concentration: > 50000 nM
Compound 3 ended at the assay's limit; the forecaster's own chance of this, stated with the estimate: 35%; at least 3.3-fold (0.52 log units) between middle value and limit.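

In this assay, putting 4-hydroxyphenyl in place of 3-hydroxyphenyl on the carbon next to the ring nitrogen gives an at least 7.8-fold higher number from compound 2 to compound 3 (0.89 log units; beyond the scatter), so where the hydroxyl sits on this ring matters, even though the two compounds hold the same atoms. The reading for compound 3 is a limit, not a number, so this step gives only a minimum size: the limit of > 50000 nM in this assay, at which 2 of the 3 values shown sit.

The step between compound 1 and compound 3 cannot be read. Still open, as far as these compounds go, is how a phenyl ring carrying an amine or a carboxylic acid in place of the hydroxyl would behave at this position.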